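From tert-butyl to 2-(methoxycarbonyl)ethyl on an aromatic nitrogen

The source may report more compounds than this note shows. Statements on the series, on what has been measured and on what is new or still open speak of the compounds shown alone.

Measured so far in a functional assay on HepG2 cells (Homo sapiens) for inhibition, read by crystal violet staining, with a stated time of 48 h; on this read-out lower numbers stand for stronger inhibition and higher numbers for weaker inhibition:
- compound 1 `CCn1sc(Cl)cc1=O`: 12000 nM
- compound 2 `CCn1c(=O)c(Cl)c(Cl)[s+]1[O-]`: > 100000 nM (a limit)
- compound 3 `CCCCCCCCCCCCSc1cc(=O)n(C(C)(C)C)[s+]1[O-]`: > 50000 nM (a limit)

Only compound 1 has a true number here. Compound 2 gives a limit, not a number. As far as these compounds go, compound 3 also gives only a limit, so its real position on the scale is unknown.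

Compound 4 `CCCCCCCCCCCCSc1cc(=O)n(CCC(=O)OC)[s+]1[O-]` has not yet been measured. It keeps the rest of compound 3 but carries 2-(methoxycarbonyl)ethyl in place of tert-butyl on an aromatic nitrogen.

For the measured compounds named here, no measured pair of compounds shows this swap, so any forecast is rough. With compound 3 at > 50000 nM, a limit, there is no number to start from, and a modest move toward stronger inhibition in this assay is the working expectation. A second limit would be no surprise. The estimated change is an at least 1.6-fold lower number from compound 3 to compound 4 (0.22 log units; that floor lies within the scatter). For compound 4 the expected value is 30000 nM, with an estimated range of 6000 nM to 100000 nM.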

Compound 4, half-maximal inhibitory concentration: > 100000 nM
Compound 4 gave a limit, no number (the forecaster's own chance of this, stated with the estimate: 45%); middle value at least 3.3-fold (0.52 log units) from the limit.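

In this assay, compound 3 and compound 4 both end at limits rather than true numbers, so swapping tert-butyl for 2-(methoxycarbonyl)ethyl gives no readable step between them. As far as these compounds go, what stays open is how strongly, if at all, compound 3 and compound 4 inhibit, and which of the two groups on the aromatic nitrogen gives stronger inhibition.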